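The source may hold more compounds than are shown below. What is called first, only, known or untested is meant among the compounds shown, and "the series" means these compounds.

Within the data shown here, in an assay on CHO cells for antagonist activity at transient receptor potential cation channel subfamily V member 1 (Homo sapiens), read by FLIPR and calcium flux (a higher number here means a weaker inhibitor, a lower number a stronger inhibitor), compound 1 `CC(C(=O)NCc1ccc(C(F)(F)F)nc1Cl)c1ccc(NS(C)(=O)=O)c(F)c1` gives 0.2 nM, and compound 2 `CC(C(=O)NCc1ccc(C(F)(F)F)nc1C1CC2CCC1C2)c1ccc(NS(C)(=O)=O)c(F)c1` gives 1.5 nM, the higher of the two numbers; the one measured step, a 7.5-fold higher number from compound 1 to compound 2 (0.88 log units; beyond the scatter), is a modest one. Compound 3 `CCC/C=C\c1nc(C(F)(F)F)ccc1CNC(=O)C(C)c1ccc(NS(C)(=O)=O)c(F)c1` differs from compound 2 as follows: a group of 5 heavy atoms (5 carbon; no ring) in place of a group of 7 heavy atoms (7 carbon; 2 five-membered non-aromatic rings of carbon only), on an aromatic carbon. Among the measured compounds shown here, only that step bears on the change, and it shows that a group larger than chlorine at this position gives a higher number. The chain entering is smaller than the group leaving, so compound 3 is expected to give 1 nM, between 0.3 nM and 4 nM, which is expected to mean a step of a 1.5-fold lower number from compound 2 to compound 3 (0.18 log units; within the scatter) within the scatter.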

Compound 3, inhibition constant: 2.1 nM
Compound 3: the middle estimate sits 2.1-fold (0.32 log units) below what was measured, within the range that was stated.
By their numbers in this assay, from the lowest: compound 1; then compounds 2 and 3 (each within the scatter of the next).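

In this assay, two quite different groups at this position sit within the scatter of each other, with a 1.4-fold higher number from compound 2 to compound 3 (0.15 log units; within the scatter), so the two five-membered non-aromatic rings are not required for a number at this level. Pent-1-en-1-yl in place of chloro gives an 11-fold higher number from compound 1 to compound 3 (1.02 log units; beyond the scatter), which shows that the rise over compound 1 also occurs with a group that has no ring. No evidence is available to explain either step. As far as these compounds go, what remains open is how a methyl group, an amine or a saturated pentyl chain would compare with chloro at this position.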